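A few compounds are considered here, and "the series" means these few. Any claim that something is new, unique, unknown or untested is made for them only; others in the source may bear on it.

Measured so far:
compound 1, `CCCCCCSc1nc2ccccc2n1CC(=O)O`, in an assay on HEK293 cells for displacement of a labelled ligand from prostaglandin D2 receptor 2 (Homo sapiens); on this read-out higher numbers stand for weaker inhibition and lower numbers for stronger inhibition: 1360 nM
compound 2, `O=C(O)Cn1c(SCc2ccc(Cl)cc2)nc2ccccc21`, in this assay: 160 nM
compound 3, `O=C(O)Cn1c(SCc2cccc(Cl)c2)nc2ccccc21`, in this assay: 186 nM

Compound 3 gives the second highest of the three numbers; its nearest neighbour is compound 2, with the two values within the scatter of each other, while compound 1 stands far above it by a 7.3-fold lower number from compound 1 to compound 3 (0.86 log units; beyond the scatter).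

Compound 4, `O=C(O)Cn1c(SCc2ccc(Br)cc2)nc2ccccc21`, differs from compound 3 by one change: 4-bromophenyl in place of 3-chlorophenyl on a saturated chain carbon bound to a sulfur.

Within the data shown here, two measured steps bear on this. The move from a pentyl chain to a chlorophenyl group on that carbon lowered the number strongly in both cases, an 8.5-fold lower number from compound 1 to compound 2 (0.93 log units; beyond the scatter) and a 7.3-fold lower number from compound 1 to compound 3 (0.86 log units; beyond the scatter). The shift of the chlorine from one ring position to the other, however, gave only a 1.2-fold higher number from compound 2 to compound 3 (0.07 log units; within the scatter), within the scatter. A bromine in place of a chlorine at the ring position of compound 2 is therefore expected to change little, so compound 4 is estimated at 150 nM, between 60 nM and 400 nM, which would mean a step of a 1.2-fold lower number from compound 3 to compound 4 (0.09 log units; within the scatter).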

Compound 4, half-maximal inhibitory concentration: 220 nM
Beside the measured number, compound 4's estimate is 1.5-fold (0.17 log units) below it; the range from low to high includes it.
By their numbers in this assay, from the lowest: compounds 2, 3 and 4 (each within the scatter of the next); then compound 1.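

In this assay, among these compounds, bromo in place of chloro on an aromatic carbon stays within the scatter (a 1.4-fold higher number from compound 2 to compound 4 (0.14 log units; within the scatter)), so the ring of compound 2 accepts a different halogen as readily as the earlier compounds showed it accepting a shift of the chlorine. The step to 4-bromophenyl from 3-chlorophenyl (a 1.2-fold higher number from compound 3 to compound 4 (0.07 log units; within the scatter)) is also within the scatter, and compounds 2, 3 and 4 cannot be separated here. Set against the pentyl chain (a 6.2-fold lower number from compound 1 to compound 4 (0.79 log units; beyond the scatter)), the 4-bromophenyl group extends the gain seen with both chlorophenyl groups to a third halogen-bearing phenyl group on a saturated chain carbon bound to a sulfur.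

Nothing measured here explains these numbers. Open, going by these compounds, is whether an unsubstituted phenyl, or a phenyl carrying a methoxy group or an amine, on that carbon would stay in the same range.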